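This account rests on a few compounds, and the source may have more. Where it says the series, first, only, none or still open, it means among the compounds named here.

Measured so far:
- compound 1 `CC(C)(N)C(=O)N[C@@H]1CCc2ccccc2N(Cc2ccc(-c3ccccc3CNC(=O)NC3CC3)cc2)C1=O` (45 nM)
- compound 2 `CC(=O)NCc1ccccc1-c1ccc(CN2C(=O)[C@H](NC(=O)CC(C)(C)N)CCc3ccccc32)cc1` (200 nM)

In a functional assay (Pituitary gland cell) with Rattus norvegicus as the target (on this read-out lower numbers stand for an effect already at smaller amounts and higher numbers for an effect only at larger amounts of compound), compound 2 has the higher of the two numbers (200 nM), and the lower number of compound 1 lies beyond the scatter from it. Compound 3 `CC(C)(N)CC(=O)N[C@@H]1CCc2ccccc2N(Cc2ccc(-c3ccccc3C(N)=O)cc2)C1=O` has carbamoyl in place of acetamidomethyl on an aromatic carbon. Among the compounds with values here, no measured pair shows this change, so the expectation is loose. A moderate step towards a lower number is expected in this assay (a 1.8-fold lower number from compound 2 to compound 3 (0.26 log units; within the scatter)), and a step within the scatter remains possible. For compound 3 the estimated value is 110 nM (expected range 35 nM to 350 nM).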

Compound 3, concentration for half-maximal effect: 80 nM
Beside the measured number, compound 3's estimate is 1.4-fold (0.14 log units) above it, within the range that was stated.
By their numbers in this assay, from the lowest: compounds 1 and 3 (each within the scatter of the next); then compound 2.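

In this assay the change from acetamidomethyl to carbamoyl on this aromatic carbon, ortho to a large group, gives the first step readable at this position (a 2.5-fold lower number from compound 2 to compound 3 (0.40 log units; beyond the scatter)), and it lies beyond the scatter. The entering group has 3 heavy atoms against 5 for the leaving one, while both have 1 hydrogen-bond donor and 1 hydrogen-bond acceptor. Nothing on hand explains the step.

Going by these compounds, whether an amine, a carboxylic acid or a longer chain on this carbon would shift the number further remains open. So does the effect of carbamoyl on the other carbons of this ring.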